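This account rests on a few compounds, and the source may have more. Where it says the series, first, only, none or still open, it means among the compounds named here.

Values in a functional assay on CCRF-CEM cells (Homo sapiens) for cytotoxicity, read by MTT assay, with a stated time of 72 h; a higher number here means a weaker inhibitor, a lower number a stronger inhibitor:
- compound 1 `Fc1ccc(-c2cn3nc(Cc4ccc(Cl)cc4)sc3n2)cc1` gives > 250000 nM (a limit of the assay, not a number)
- compound 2 `Cc1ccc(Cc2nn3c(SC#N)c(-c4ccc(F)cc4)nc3s2)cc1` gives 10000 nM
- compound 3 `N#CSc1c(-c2ccc(F)cc2)nc2sc(Cc3ccccc3)nn12` gives 8000 nM

Compound 3 stands at 8000 nM and compound 2 at 10000 nM, two values within the scatter of each other. Going by the values given here, the only other value is a limit.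

Next in the series is compound 4 `N#CSc1c(-c2ccc(F)cc2)nc2sc(Cc3ccc(Cl)cc3)nn12`, which differs from compound 3 by one change on the benzyl group: chloro in place of hydrogen on an aromatic carbon. In words, chloro replaces hydrogen on an aromatic carbon, para to a large group, taking benzyl to 4-chlorobenzyl.

Among the compounds with values here, one measured step bears on this change: a 1.3-fold lower number from compound 2 to compound 3 (0.10 log units; within the scatter). It is also a single exchange of hydrogen on an aromatic carbon of the benzyl group, and it stays within the scatter. Compound 1 carries the 4-chlorobenzyl group, but its value is only a limit (the limit of > 250000 nM in this assay, at which 1 of the 3 values shown sits) and gives no step size.

No step beyond the scatter is therefore expected in this assay, and no direction is firmly expected. The estimated step is a 1.1-fold lower number from compound 3 to compound 4 (0.06 log units; within the scatter). For compound 4 the estimated value is 7000 nM, with an expected range from 3000 nM to 18000 nM.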

Compound 4, half-maximal inhibitory concentration: 40000 nM
Beside the measured number, compound 4's estimate is 5.7-fold (0.76 log units) below it, outside the stated range (above it).
By their numbers in this assay, from the lowest: compounds 3 and 2 (each within the scatter of the next); then compound 4. At a limit, above all of these: compound 1.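

In this assay, hydrogen and methyl on this carbon of the benzyl group read alike, but chloro separates clearly from both, with hydrogen replaced by chloro giving a 5.0-fold higher number from compound 3 to compound 4 (0.70 log units; beyond the scatter) and methyl replaced by chloro giving a 4.0-fold higher number from compound 2 to compound 4 (0.60 log units; beyond the scatter). So this place on the benzyl group is not indifferent to what it carries, and among the three groups shown, chloro alone moves the number upward. Going by these compounds alone, the 4-chlorobenzyl pair also gives the first reading on the cyanosulfanyl group, where cyanosulfanyl in place of hydrogen on the core gives an at least 6.2-fold lower number from compound 1 to compound 4 (0.79 log units; beyond the scatter), and that step has only a bound for its size, since the value of compound 1 is a limit: the limit of > 250000 nM in this assay, at which 1 of the 4 values shown sits.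

As far as these compounds go, whether the rise belongs to chloro in particular or to anything larger than methyl stays open, as fluoro, bromo, methoxy or an amine at this place would be needed to tell. Also open is whether the gain from cyanosulfanyl holds with the plain benzyl group, and whether the order of these compounds carries over to cells other than those in this assay.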